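Swapping (4-methoxyphenyl)amino for azetidin-1-yl on the shared core

The source may hold more compounds than are shown below. What is called first, only, known or untested is meant among the compounds shown, and "the series" means these compounds.

In a functional assay on MCF7 cells (Homo sapiens) for inhibition, read by sulforhodamine B assay (on this read-out lower numbers stand for stronger inhibition and higher numbers for weaker inhibition), compound 1 (`O=C1C(Nc2ccccc2)=CC(=O)c2c1nc1n2[C@H]2OC[C@@H](O)[C@H]2OC1`) gives > 4000 nM as its result, which is a limit and not a number. Compound 2 (`O=C1C(Nc2ccc(Br)cc2)=CC(=O)c2c1nc1n2[C@H]2OC[C@@H](O)[C@H]2OC1`) gives 4330 nM on the same read-out. Compound 3 (`COc1ccc(NC2=CC(=O)c3c(nc4n3[C@H]3OC[C@@H](O)[C@H]3OC4)C2=O)cc1`) gives 4470 nM and stands level with compound 2, the only other true number, as shown by a 1.0-fold higher number from compound 2 to compound 3 (0.01 log units; within the scatter) for methoxy in place of bromo on an aromatic carbon.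

Compound 4 (`O=C1C(N2CCC2)=CC(=O)c2c1nc1n2[C@H]2OC[C@@H](O)[C@H]2OC1`) has azetidin-1-yl in place of (4-methoxyphenyl)amino on a double-bonded ring carbon. Going by the values given here, no measured step makes this exchange. The steps for bromo and methoxy in place of hydrogen, a step that the limit leaves unreadable from compound 1 to compound 2 and a step that the limit leaves unreadable from compound 1 to compound 3, give no size. Among the compounds with values here, the step from compound 2, with compound 3 at 4470 nM as its end point, is the only readable guide, and it points to no expected change beyond the scatter in this assay as a firm call. The expected step is a 1.5-fold lower number from compound 3 to compound 4 (0.17 log units; within the scatter) with wide uncertainty. For compound 4 the estimated value is 3000 nM with an expected range from 600 nM to 10000 nM as its bounds.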

Compound 4, half-maximal inhibitory concentration: > 16000 nM
Compound 4: no number, only a limit; the forecaster's own chance of this, stated with the estimate: 30%; at least 5.3-fold (0.72 log units) between middle value and limit.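

In this assay compound 4 gives > 16000 nM, which is a limit and not a number. Even so, the double-bonded ring carbon now shows a change beyond the scatter, which the exchange of bromo and methoxy on the aromatic ring did not: azetidin-1-yl in place of (4-methoxyphenyl)amino gives an at least 3.5-fold higher number from compound 3 to compound 4 (0.55 log units; beyond the scatter), and azetidin-1-yl in place of (4-bromophenyl)amino gives an at least 3.6-fold higher number from compound 2 to compound 4 (0.56 log units; beyond the scatter), with higher numbers meaning weaker inhibition. The step from compound 1 to compound 4 joins two limits and cannot be read.

The compounds shown leave open whether the weaker inhibition goes with losing the aromatic ring or with losing the hydrogen-bond donor, as the exchange removes both at once. They also do not say how a benzylamino or a morpholin-4-yl group on this carbon would read.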